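The source may report more compounds than this note shows. Statements on the series, on what has been measured and on what is new or still open speak of the compounds shown alone.

Compound 1 `CC(C)[C@H](NC(=O)COc1cccc2ccccc12)C(=O)N[C@@H](CC(=O)O)C(=O)COc1cccc2ccccc12`, compound 2 `CC(C)[C@H](NC(=O)COc1cccc2ccccc12)C(=O)N[C@@H](CC(=O)O)C(=O)COc1ccc(C(F)(F)F)cc1` and compound 3 `CC(C)[C@H](NC(=O)COc1cccc2ccccc12)C(=O)N[C@@H](CC(=O)O)C(=O)COc1cc(F)ccc1F` share one core and differ only in the group on an oxygen on a saturated carbon. In a functional assay with Homo sapiens as the target (a lower number here means a stronger inhibitor, a higher number a weaker inhibitor), compound 1 gives 19000 nM, compound 2 gives 12300 nM and compound 3 gives 19700 nM. Compound 3 therefore stands level with the other two, as all three numbers lie within the scatter of one another.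

Compound 4 `CC(C)[C@H](NC(=O)COc1cccc2ccccc12)C(=O)N[C@@H](CC(=O)O)C(=O)COc1cc(F)c(F)cc1F` differs from compound 3 in one place: fluoro in place of hydrogen on an aromatic carbon. This fluoro in place of hydrogen on an aromatic carbon turns 2,5-difluorophenyl into 2,4,5-trifluorophenyl.

For the measured compounds named here, no measured step makes this exact change, so the evidence is indirect. Three steps exchange the whole group at this site: a 1.5-fold lower number from compound 1 to compound 2 (0.19 log units; within the scatter), a 1.0-fold higher number from compound 1 to compound 3 (0.02 log units; within the scatter) and a 1.6-fold higher number from compound 2 to compound 3 (0.20 log units; within the scatter). All three stay within the scatter, so no step beyond the scatter is expected in this assay.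

The estimated step is a 1.2-fold lower number from compound 3 to compound 4 (0.09 log units; within the scatter). Compound 4 is expected at 16000 nM, with an estimated range of 8000 nM to 30000 nM.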

Compound 4, half-maximal inhibitory concentration: 16700 nM
The estimate for compound 4 lay 1.0-fold (0.02 log units) below the measured number, within the range that was stated.
By their numbers in this assay, from the lowest: compounds 2, 4, 1 and 3 (each within the scatter of the next).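

Fluoro in place of hydrogen, para to a large group on this ring, is the first single-atom change read at this site, and in this assay it gives a 1.2-fold lower number from compound 3 to compound 4 (0.07 log units; within the scatter) and so no real change. The exchanges of the whole group agree, with a 1.4-fold higher number from compound 2 to compound 4 (0.13 log units; within the scatter) and a 1.1-fold lower number from compound 1 to compound 4 (0.06 log units; within the scatter) both lying within the scatter, so 2,4,5-trifluorophenyl stands level with 4-(trifluoromethyl)phenyl and naphthalen-1-yl, and all four compounds now read alike at this site. No supporting measurement bears on why these numbers stay level.

Every group at this site so far is an aromatic ring, bare or carrying fluoro or trifluoromethyl. Going by these compounds, whether an amine on the ring, or a longer saturated chain in place of the ring, would move the number beyond the scatter remains open.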